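The source may hold more compounds than are shown below. What is called first, only, known or untested is meant among the compounds shown, and "the series" means these compounds.

Measured so far: compound 1 `NC(=O)c1c(NC(=O)c2ccccc2F)sc2c1CCN(Cc1ccc(Cl)cc1Cl)C2` with 27500 nM in a functional assay on HeLa cells (Homo sapiens) for antiproliferative activity, with a stated time of 24 h (a higher number here means a weaker inhibitor, a lower number a stronger inhibitor), and compound 2 `NC(=O)c1c(NC(=O)c2ccccc2F)sc2c1CCN(C(=S)Nc1ccccc1Cl)C2` with 19400 nM in the same assay.

Among these two numbers compound 2 has the lower one, but the step of a 1.4-fold lower number from compound 1 to compound 2 (0.15 log units; within the scatter) lies within the scatter, so the two compounds cannot be told apart on this evidence. Compound 3 `NC(=O)c1c(NC(=O)c2ccccc2F)sc2c1CCN(C(=O)Nc1ccccc1Cl)C2` has not yet been measured in this assay. It differs from compound 2 in one place: a group of 10 heavy atoms (7 carbon, 1 nitrogen, 1 oxygen, 1 chlorine; one six-membered aromatic ring of carbon only) in place of a group of 10 heavy atoms (7 carbon, 1 nitrogen, 1 sulfur, 1 chlorine; one six-membered aromatic ring of carbon only), on an amine nitrogen in a ring. Within the data shown here, the only measured step, from compound 1 to compound 2, exchanges the whole group on that ring nitrogen for a differently built one and says nothing direct about swapping a sulfur for an oxygen inside an otherwise equal group; it was itself within the scatter. Among the measured compounds shown here, no measured step therefore bears on the change from compound 2 to compound 3, and no shift beyond the scatter is expected in this assay. The estimate for compound 3 is 20000 nM, with a range from 8000 nM to 50000 nM, which is expected to amount to the step of a 1.0-fold higher number from compound 2 to compound 3 (0.01 log units; within the scatter).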

Compound 3, half-maximal inhibitory concentration: > 50000 nM
Compound 3 was reported as a limit (the forecaster's own chance of this, stated with the estimate: 10%); middle value at least 2.5-fold (0.39 log units) from the limit.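

In this assay the entry for compound 3, > 50000 nM, is a limit of the assay and not a number. Among these compounds, exchanging only the sulfur for an oxygen, in an otherwise equal group on an amine nitrogen in a ring, gives an at least 2.5-fold higher number from compound 2 to compound 3 (0.41 log units; beyond the scatter), the first step that clears the scatter, so this position responds to a single atom within the group, something the earlier pair could not show, since its change of the whole group stayed within the scatter. The comparison of (2-chlorophenyl)carbamoyl with 2,4-dichlorobenzyl is less decisive, giving an at least 1.8-fold higher number from compound 1 to compound 3 (0.25 log units; that floor lies within the scatter), so on this evidence the carbamoyl group can be separated clearly only from the sulfur-bearing group and not from the benzyl group.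

The compounds shown leave open how large either step truly is, as each gives only a floor: the limit of > 50000 nM in this assay, at which 1 of the 3 values shown sits. They also leave open whether the same exchange of sulfur for oxygen would matter with an unsubstituted phenyl ring, a pyridine ring or a methoxy group in place of the chlorine in this group.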